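Pyridyl Swap on a Thiophene Sulfonamide Against Trypsin

This account rests on a few compounds, and the source may have more. Where it says the series, first, only, none or still open, it means among the compounds named here.

Compound 1 `N=C(N)c1cccc(CN2CC[C@H](NS(=O)(=O)c3ccc(-c4ccncc4)cc3)C2=O)c1`: > 2900 nM
Compound 2 `N=C(N)c1cccc(CN2CC[C@H](NS(=O)(=O)c3ccc(-c4ccccn4)s3)C2=O)c1`: > 2100 nM

In an assay on isolated protein for inhibition of Trypsin II (Bos taurus) (a lower number here means a stronger inhibitor, a higher number a weaker inhibitor), compound 1 gives > 2900 nM, which is a limit of the assay rather than a number. Compound 2 likewise reaches only a limit, > 2100 nM, so compound 2 stands at the weak end of what is shown. Compound 3 `N=C(N)c1cccc(CN2CC[C@H](NS(=O)(=O)c3ccc(-c4ccncc4)s3)C2=O)c1` carries pyridin-4-yl in place of pyridin-2-yl on an aromatic carbon. No measured step connects the two, and nothing shown points toward a gain, so the change is expected to shift the inhibition constant in this assay by little beyond the scatter. The estimated step from compound 2 to compound 3 is a step that the limit leaves unreadable from compound 2 to compound 3. Compound 3 is therefore expected at 5000 nM, within 2000 nM to 20000 nM.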

Compound 3, inhibition constant: > 2900 nM
Compound 3: only a limit was reported (the forecaster's own chance of this, stated with the estimate: 80%); the middle value does not contradict the limit.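

Among these compounds, compound 2 and compound 3 each reach only a limit of the assay, so no step between them can be read. The compounds shown leave open whether pyridin-4-yl and pyridin-2-yl differ at all in inhibition constant.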